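Mirror-Image Change at One Ring Carbon

This account rests on a few compounds, and the source may have more. Where it says the series, first, only, none or still open, it means among the compounds named here.

- compound 1 `CC1=NN(c2ccccc2)C(=O)[C@@]12C(=O)C=CC[C@@H]2c1ccccc1[N+](=O)[O-]`: 68300 nM
- compound 2 `CC1=NN(c2ccccc2)C(=O)[C@]12C(=O)C=CC[C@H]2c1ccc(C)cc1`: 5720 nM
- compound 3 `CC1=NN(c2ccccc2)C(=O)[C@@]12C(=O)C=CC[C@H]2c1ccc(C)cc1`: 8300 nM

In a functional assay on MDA-MB-231 cells (Homo sapiens) for inhibition, read by MTT assay, with a stated time of 72 h (a higher number here means a weaker inhibitor, a lower number a stronger inhibitor), compound 3 gives 8300 nM, within the scatter of compound 2, while compound 1 has the clearly higher 68300 nM. The next compound, compound 4 `CC1=NN(c2ccccc2)C(=O)[C@@]12C(=O)C=CC[C@@H]2c1ccc(C)cc1`, has the same atoms and bonds as compound 3: the two compounds have the same atoms and bonds and differ only in configuration as drawn: 1 of 2 stereo elements differ; a stereocentre at a saturated ring carbon is drawn S in compound 3 and R in compound 4. A stereocentre at a saturated ring carbon is drawn S in compound 3 and R in compound 4.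

Among the compounds with values here, one measured step bears on this change: a 1.5-fold higher number from compound 2 to compound 3 (0.16 log units; within the scatter). It lies within the scatter, and it is the closest guide because of the fact that compounds 2 and 3 differ only in the configuration as drawn. Within the data shown here, it is only a single example, so the guidance is limited. A change of configuration at this carbon is therefore expected to make no difference beyond the scatter, and no direction can be favoured. The expected step is a 1.1-fold lower number from compound 3 to compound 4 (0.04 log units; within the scatter). For compound 4 the estimated value is 7500 nM, with an expected range of 3500 nM to 16000 nM.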

Compound 4, half-maximal inhibitory concentration: 7420 nM
Estimate against measurement, compound 4: 1.0-fold (0.00 log units) above, within the range that was stated.
By their numbers in this assay, from the lowest: compounds 2, 4 and 3 (each within the scatter of the next); then compound 1.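

Compound 4 completes a set of 4-methylphenyl compounds in which configuration shows no effect beyond the scatter in this assay: the number shifts by a 1.1-fold lower number from compound 3 to compound 4 (0.05 log units; within the scatter), and by a 1.3-fold higher number from compound 2 to compound 4 (0.11 log units; within the scatter). The group on this saturated ring carbon matters more than its drawn configuration, as swapping 2-nitrophenyl for 4-methylphenyl gives a 9.2-fold lower number from compound 1 to compound 4 (0.96 log units; beyond the scatter). The mirror-image pair is the strictest test of configuration here, as nothing else changes: the fact that compounds 2 and 4 differ only in the configuration as drawn

On these data alone, whether configuration is equally unimportant with 2-nitrophenyl on this carbon remains open, as does whether the larger step comes from losing the nitro group or from the different place of the substituent on the phenyl ring. Also open, as far as these compounds go, is what an amine or a carboxylic acid on that phenyl ring would give.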